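The compounds below may be only part of what the source reports. "The series", "measured", "known", "first", "only" and "open" are said of these compounds alone.

Compound 1 `CC(C)N(c1cc(C#CC(C)(C)C)sc1C(=O)O)C(=O)[C@H]1CC[C@H](C)CC1`: in an ADME assay for protein binding, using equilibrium dialysis, at pH 7.4, tested at 2 uM (on this read-out lower numbers stand for a smaller free fraction and higher numbers for a larger free fraction), compound 1 gives 0.06.
Compound 2 `CC(C)N(c1cc(C#CC(C)(C)C)sc1C(=O)O)C(=O)[C@H]1CC[C@H](Cl)CC1`: compound 2 gives 0.14.
Compound 3 `CC(C)N(c1cc(C#CC(C)(C)C)sc1C(=O)O)C(=O)[C@H]1CC[C@H](CF)CC1`: compound 3 gives 0.18.

Compound 3 holds the highest of the three numbers, though its gap to compound 2 is within the scatter; only compound 1 sits clearly lower. Compound 4 `CC(C)N(C(=O)C1CCC(F)(F)CC1)c1cc(C#CC(C)(C)C)sc1C(=O)O` differs from compound 3 in one place: 4,4-difluorocyclohexyl in place of 4-(fluoromethyl)cyclohexyl on a carbonyl carbon. Within the data shown here, two measured steps bear on this: a 2.3-fold higher number from compound 1 to compound 2 (0.37 log units; beyond the scatter) and a 3.0-fold higher number from compound 1 to compound 3 (0.48 log units; beyond the scatter), both modest rises where chloro replaced methyl or fluoro replaced hydrogen. The step of a 1.3-fold higher number from compound 2 to compound 3 (0.11 log units; within the scatter) shows that exchanging chloro for fluoromethyl left the number within the scatter. Compound 4 is therefore expected to show a small rise or none beyond the scatter, a 1.2-fold higher number from compound 3 to compound 4 (0.09 log units; within the scatter). Compound 4 is estimated at 0.22, with a range from 0.12 to 0.4.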

Compound 4, unbound fraction: 0.4
Compound 4: middle estimate off by 1.8-fold (0.26 log units), on the low side; low and high end bracket the measured number.
By their numbers in this assay, from the lowest: compound 1; then compounds 2 and 3 (each within the scatter of the next); then compound 4.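

Placing 4,4-difluorocyclohexyl on the carbonyl carbon lifts the free fraction clear of every earlier group at this position, with a 2.2-fold higher number from compound 3 to compound 4 (0.35 log units; beyond the scatter), a 2.9-fold higher number from compound 2 to compound 4 (0.46 log units; beyond the scatter) and a 6.7-fold higher number from compound 1 to compound 4 (0.82 log units; beyond the scatter) in this assay. The earlier exchange of chloro for fluoromethyl could not be told apart from scatter, so this result shows that this position can still move the number further. Nothing measured here explains the rise. Still open, going by these compounds, is whether 4,4-dimethylcyclohexyl, with methyl groups in place of both fluorines, would give a similar number. A cyclohexyl ring carrying an amine or a hydroxyl group also remains an open case.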